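A few compounds are considered here, and "the series" means these few. Any claim that something is new, unique, unknown or untested is made for them only; others in the source may bear on it.

Of the compounds shown here, two built on the same core have been tested in an ADME assay on NIH3T3 cells (Mus musculus) for cytotoxicity, read by MTT assay, with a stated time of 24 h; a lower number here means a stronger inhibitor, a higher number a weaker inhibitor. Compound 1 `Cc1nnc(SCC(=O)N/N=c2/scc(-c3ccccc3)n2-c2ccccc2)s1` gives 197 ug/mL, and compound 2 `O=C(CSc1ncccn1)N/N=c1/scc(-c2ccccc2)n1-c1ccccc1` gives 107 ug/mL; the step of a 1.8-fold lower number from compound 1 to compound 2 (0.27 log units; within the scatter) lies within the scatter, so the two cannot be told apart. Compound 3 `Cc1nnc(SCC(=O)N/N=c2/scc(-c3ccc(Br)cc3)n2-c2ccccc2)s1` differs from compound 1 by bromo in place of hydrogen on an aromatic carbon. Within the data shown here, the one measured step changes a different part of the molecule, so no step bears on this change, and nothing beyond the scatter is expected in this assay. The expected value for compound 3 is 150 ug/mL, in the range 70 ug/mL to 320 ug/mL, and the step of a 1.3-fold lower number from compound 1 to compound 3 (0.12 log units; within the scatter) is expected to stay within the scatter.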

Compound 3, half-maximal inhibitory concentration: 55 ug/mL
Compound 3: middle estimate off by 2.7-fold (0.44 log units), on the high side; the whole stated range lies above it.
By their numbers in this assay, from the lowest: compounds 3, 2 and 1 (each within the scatter of the next, the first and the last beyond it).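

Bromo on this six-membered aromatic ring gives the first step shown that clearly exceeds the scatter: in this assay, the change from phenyl to 4-bromophenyl gives a 3.6-fold lower number from compound 1 to compound 3 (0.55 log units; beyond the scatter) and is modest in size. A single added heavy atom on this ring therefore registers in this assay, whereas the earlier change on the sulfur did not. No available evidence explains this shift.

Going by these compounds, whether chloro, methoxy or an amine on the same carbon would shift the number similarly remains open. So does whether bromo would produce a similar step alongside the pyrimidin-2-yl group of compound 2.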